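The source may hold more compounds than are shown below. What is called first, only, known or untested is meant among the compounds shown, and "the series" means these compounds.

In an ADME assay on the whole organism (strain FVB) for pharmacokinetics, with Mus musculus as the target, read by LC-MS, at a dose of 30 mg/kg by the oral route (on this read-out lower numbers stand for lower exposure and higher numbers for higher exposure at the dose given), compound 1 `CC(C)(O)CNCCCOc1ccc([C@H]2CC[C@]3(CC2)OOC2(O3)C3CC4CC(C3)CC2C4)cc1` gives 11100 ng.h/mL and compound 2 `CC(C)(N)CCOc1ccc([C@H]2CC[C@]3(CC2)OOC2(O3)C3CC4CC(C3)CC2C4)cc1` gives 12300 ng.h/mL, so compound 2 stands level with compound 1 within the scatter. The unmeasured compound 3 `NCCCCOc1ccc([C@H]2CC[C@]3(CC2)OOC2(O3)C3CC4CC(C3)CC2C4)cc1` departs from compound 2 at a single place: 2-aminoethyl in place of 1-amino-1-methylethyl on a saturated chain carbon, two bonds along the chain from an oxygen on an aromatic ring. Within the data shown here, only one measured step bears on this change, a 1.1-fold higher number from compound 1 to compound 2 (0.04 log units; within the scatter), made at the same place but with different groups, and it offers no ground for expecting a step beyond the scatter. The expected step is a 1.4-fold lower number from compound 2 to compound 3 (0.16 log units; within the scatter), slightly downward if anything. For compound 3 the estimated value is 8500 ng.h/mL, with an expected range of 3500 ng.h/mL to 20000 ng.h/mL.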

Compound 3, area under the concentration-time curve: 4700 ng.h/mL
The estimate for compound 3 lay 1.8-fold (0.26 log units) above the measured number; measured number inside the range.
By their numbers in this assay, from the lowest: compound 3; then compounds 1 and 2 (each within the scatter of the next).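

In this assay, replacing 3-amino-3-methylbutoxy with 4-aminobutoxy gives a 2.6-fold lower number from compound 2 to compound 3 (0.42 log units; beyond the scatter), so this position can move exposure beyond the scatter, which the earlier pair had not shown. The change from the side chain of compound 1 to aminomethyl likewise gives a 2.4-fold lower number from compound 1 to compound 3 (0.37 log units; beyond the scatter). Of these three compounds, only compound 3, with the unbranched chain, stands apart.

Nothing available explains the drop in exposure. As far as these compounds go, whether a single methyl group on the carbon bearing the amine, or a longer chain, would restore exposure remains open.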